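The source may report more compounds than this note shows. Statements on the series, on what has been measured and on what is new or still open speak of the compounds shown alone.

In an assay on isolated protein for inhibition of Nitric oxide synthase, inducible (Homo sapiens), read by scintillation counting, with a stated time of 30 min, tested at 50 uM (on this read-out higher numbers stand for more inhibition at the one concentration tested (going by the name of the read-out) and lower numbers for less inhibition), compound 3 `CC(=O)N1N=C(c2cc(Cl)ccc2N)SC1(C)C` gives 72.8%, the second highest of three numbers. Compound 1 `COc1ccc(N)c(C2=NN(C(C)=O)C(C)(C)S2)c1` gives 77.1%, and the step of a number 4.3 percentage points lower from compound 1 to compound 3 (within the scatter) lies within the scatter. Compound 2 `CC1(C)SC(c2ccccc2N)=NN1C(=O)c1ccccc1` gives 39.8%, far below compound 3. Compound 4 `CC1(C)SC(c2cc(Cl)ccc2N)=NN1C(=O)C1CCC1` differs from compound 3 by cyclobutyl in place of methyl on a carbonyl carbon. Going by the values given here, no measured step alters only the group on the carbonyl carbon; compound 2 carries a larger group there than compound 1 but also lacks the methoxy, so its low value cannot be tied to one change. Still, that comparison suggests a drop, and compound 4 is expected to show the step of a number 17.8 percentage points lower from compound 3 to compound 4 (beyond the scatter). The value estimated for compound 4 is 55%, within 30% to 78%.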

Compound 4, a percentage reported as inhibition, at one concentration (the size of the read-out at that concentration, not a potency): -4.65%
Compound 4: the middle estimate sits 59.7 percentage points above what was measured, and the stated range ends above it.
By their numbers in this assay, from the lowest: compound 4; then compound 2; then compounds 3 and 1 (each within the scatter of the next).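

In this assay, putting cyclobutyl in place of methyl on a carbonyl carbon gives a number 77.5 percentage points lower from compound 3 to compound 4 (beyond the scatter), the first step shown that alters only this group. At this position, then, that one change is enough to take a clearly inhibiting compound down to essentially no inhibition. No measurement here accounts for the loss.

The compounds shown leave open whether the drop needs the four-membered ring or only the extra carbons. An ethyl or cyclopropyl group on the same carbonyl carbon would separate these two readings.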